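From a Urea to an Unsaturated Amide on a Shared Core

The source may hold more compounds than are shown below. What is called first, only, known or untested is meant among the compounds shown, and "the series" means these compounds.

Compound 1 `O=C(Nc1cccc(F)c1)N[C@@H]1C2CCN(CC2)[C@@H]1Cc1cccnc1` is a urea built on a shared core. In an assay on a protein complex for binding affinity to Neuronal acetylcholine receptor; alpha4/beta2 (Homo sapiens) (on this read-out lower numbers stand for stronger inhibition and higher numbers for weaker inhibition), compound 1 gives > 10000 nM, which is a limit of the assay rather than a number. Compound 2 `O=C(Nc1cccc(C(F)(F)F)c1)N[C@@H]1C2CCN(CC2)[C@@H]1Cc1cccnc1` carries a trifluoromethyl in place of fluoro on an aromatic carbon. In this assay compound 2 gives > 10000 nM, also a limit. The step that the two limits leave unreadable from compound 1 to compound 2 stays unreadable because of the limit of > 10000 nM in this assay, at which 2 of the 2 values shown sit. Compound 3 `C/C(=C\C(=O)N[C@@H]1C2CCN(CC2)[C@@H]1Cc1cccnc1)c1ccccc1` differs from compound 1 by 2-phenylprop-1-en-1-yl in place of (3-fluorophenyl)amino on a carbonyl carbon. Among the compounds with values here, no measured step covers this change, so no direction beyond the scatter can be foreseen. Compound 3 is expected at 3000 nM, between 300 nM and 30000 nM. The expected step of an at least 3.3-fold lower number from compound 1 to compound 3 (0.52 log units; beyond the scatter) cannot be sized from a limit.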

Compound 3, inhibition constant: > 10000 nM
Compound 3 was reported as a limit (the forecaster's own chance of this, stated with the estimate: 50%); middle value at least 3.3-fold (0.52 log units) from the limit.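

No step can be read from compound 1 to compound 3, since both stand only as limits and neither gives a number: the limit of > 10000 nM in this assay, at which 3 of the 3 values shown sit.
The compounds shown leave open whether any group on the carbonyl carbon of the shared core gives a readable value in this assay.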